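The source may hold more compounds than are shown below. What is called first, only, known or untested is meant among the compounds shown, and "the series" means these compounds.

Measured compounds, solubility:

compound 1 `CC(C)(NC(=O)Nc1ccc(F)c(C(F)(F)F)c1)C(=O)O` — 25 ug/mL
compound 2 `CC(C)(NC(=O)Nc1ccccc1)C(=O)O` — a limit, > 100 ug/mL
compound 3 `CC(C)(C(=O)O)N1CCCN(c2ccc(F)c(C(F)(F)F)c2)C1=O` — a limit, > 100 ug/mL

All three were run in a physicochemical assay for solubility, read by nephelometry, measured as kinetic solubility, at pH 2, tested at 10 mg/mL; a higher number here means a more soluble compound, a lower number a less soluble compound. Compound 1 gives 25 ug/mL. The readout for compound 2 is a limit of the assay, > 100 ug/mL. The readout for compound 3 is likewise a limit, > 100 ug/mL. Among the compounds with values here, compound 1 therefore holds the only actual number in this assay; the other two sit at the limit of > 100 ug/mL in this assay, at which 2 of the 3 values shown sit. Within the data shown here, no pair of measured compounds differs in a single place, so no measured step is available.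

Compound 4 `CC(C)(CC(=O)Nc1ccc(F)c(C(F)(F)F)c1)C(=O)O` is not yet measured. It differs from compound 1 by 2-carboxy-2-methylpropyl in place of (1-carboxy-1-methylethyl)amino on a carbonyl carbon. Among the measured compounds shown here, with no measured step of this kind, the expectation for compound 4 is a step from compound 1 no larger than the scatter, a 1.2-fold higher number from compound 1 to compound 4 (0.08 log units; within the scatter). The estimate for compound 4 in this assay is 30 ug/mL, within 10 ug/mL to 100 ug/mL.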

Compound 4, solubility: 25 ug/mL
Estimate against measurement, compound 4: 1.2-fold (0.08 log units) above; the range from low to high includes it.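

Within the data shown here, replacing (1-carboxy-1-methylethyl)amino with 2-carboxy-2-methylpropyl on a carbonyl carbon gives the first readable step in this assay, with no change at the digits printed from compound 1 to compound 4 (within the scatter). The exchange removes a nitrogen and a hydrogen-bond donor from this group without a step beyond the scatter. Compound 4 also gives a number, whereas compounds 2 and 3 give only a limit: the limit of > 100 ug/mL in this assay, at which 2 of the 4 values shown sit.

On these data alone, whether this holds for other groups on this carbonyl carbon, such as a longer chain or a chain ending in an amine, stays open. Also open, as far as these compounds go, is replacing the carboxylic acid itself with a primary amide or a tetrazole.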